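Para substituent exchange on the aryl ring, bromo to trifluoromethyl

The compounds below may be only part of what the source reports. "The series", "measured", "known", "first", "only" and "open" are said of these compounds alone.

Values in a functional assay on the whole organism for inhibition, with Rattus norvegicus as the target, at a dose of 30 mg/kg; a higher number here means more inhibition at the dose given (going by the name of the read-out), a lower number less inhibition:
compound 1 `CCOC(=O)C(=O)Nc1ccc(-c2nc(N)n(/C(S)=N/C)n2)cc1` gives 49%
compound 2 `C/N=C(\S)n1nc(-c2ccc(F)cc2)nc1N` gives 73%
compound 3 `C/N=C(\S)n1nc(-c2ccc(Br)cc2)nc1N` gives 88%

Compound 3 stands highest of the three numbers; the steps of a number 15 percentage points higher from compound 2 to compound 3 (beyond the scatter) and a number 39 percentage points higher from compound 1 to compound 3 (beyond the scatter) both lie beyond the scatter. Compound 4 `C/N=C(\S)n1nc(-c2ccc(C(F)(F)F)cc2)nc1N` differs from compound 3 by trifluoromethyl in place of bromo on an aromatic carbon. For the measured compounds named here, the steps that bear on this exchange all replace the group on the same aromatic carbon: a number 24 percentage points higher from compound 1 to compound 2 (beyond the scatter), a number 39 percentage points higher from compound 1 to compound 3 (beyond the scatter) and a number 15 percentage points higher from compound 2 to compound 3 (beyond the scatter), modest to large. Going by the values given here, no measured step places trifluoromethyl there, so the direction of the change is not fixed by the data. A step within the scatter or a modest fall from the highest number is expected: a number 10 percentage points lower from compound 3 to compound 4 (within the scatter). Compound 4 is estimated at 78%, with a range from 60% to 92%.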

Compound 4, a percentage reported as inhibition, in the whole organism at one dose (the size of the read-out at that dose, not a potency): 91%
For compound 4 the middle estimate is 13 percentage points below the measured one; low and high end bracket the measured number.
By their numbers in this assay, from the lowest: compound 1; then compound 2; then compounds 3 and 4 (each within the scatter of the next).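

In this assay, trifluoromethyl on this aromatic carbon cannot be told apart from bromo (a number 3 percentage points higher from compound 3 to compound 4 (within the scatter)), so a second group now sits at the top of the range. The exchange from the other two groups is clearer, modest from fluoro (a number 18 percentage points higher from compound 2 to compound 4 (beyond the scatter)) and large from ((ethoxycarbonyl)carbonyl)amino (a number 42 percentage points higher from compound 1 to compound 4 (beyond the scatter)). Nothing available explains why these groups read alike. Still open, from the compounds shown here alone, is whether a nitrile, a methoxy group or a carboxylic acid on this carbon would hold the number at this level. Going by these compounds, an unsubstituted ring is also open as a reference point.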